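This account rests on a few compounds, and the source may have more. Where it says the series, first, only, none or still open, it means among the compounds named here.

Measured in a functional assay on OVCAR-3 cells (Homo sapiens) for inhibition, read by sulforhodamine B assay, with a stated time of 48 h; a higher number here means a weaker inhibitor of growth, a lower number a stronger inhibitor of growth:
- Compound 1 `CCOC(=O)c1nn(-c2ccccc2)c(-c2ccccc2)c1CNC(C)(C)C`: 1010 nM; 195000 nM (2 entries) (two entries)
- Compound 2 `CC(C)(C)NCc1c(C(=O)O)nn(-c2ccccc2)c1-c1ccc(Br)cc1`: > 585000 nM (a limit of the assay, not a number)

The two entries for compound 1 lie far apart, as the several entries of compound 1 in this assay, 1010 nM; 195000 nM (2 entries) shows, so it offers only a loose reference point. Compound 2 has no single number in this assay, only the limit > 585000 nM.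

Compound 3 `CC(C)(C)NCc1c(C(=O)O)nn(-c2ccccc2)c1-c1ccccc1` differs from compound 2 in one place: hydrogen in place of bromo on an aromatic carbon. This puts hydrogen in place of bromo on an aromatic carbon, turning 4-bromophenyl into phenyl.

Going by the values given here, no measured pair shows what this change does. With only the limit for compound 2 to go on, no step beyond the scatter is expected in this assay, and growth inhibition is expected to stay weak. The expected change is an at least 1.1-fold lower number from compound 2 to compound 3 (0.06 log units; that floor lies within the scatter). Compound 3 is estimated at 500000 nM, with an expected range of 150000 nM to 900000 nM.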

Compound 3, concentration for 50% growth inhibition: > 716000 nM
Compound 3: no number, only a limit (the forecaster's own chance of this, stated with the estimate: 60%); middle value at least 1.4-fold (0.15 log units) from the limit.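

In this assay, going by these compounds alone, compound 2 and compound 3 each carry only a limit of the assay, not a number, and no step between them can be read. As far as these compounds go, what the change from 4-bromophenyl to phenyl does to growth inhibition stays open.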